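Hydroxyphenyl in Place of Methylthiophenyl: an Expected Step

The source may hold more compounds than are shown below. What is called first, only, known or untested is meant among the compounds shown, and "the series" means these compounds.

Of the compounds shown here, three built on one shared core have been tested in a functional assay on DU-145 cells (Homo sapiens) for inhibition, read by trypan blue exclusion, with a stated time of 96 h; a higher number here means a weaker inhibitor of growth, a lower number a stronger inhibitor of growth. Compound 2 `Cc1ccc(CS/C(=C/c2sccc2C)C(=O)c2ccc(Cl)cc2)cc1` gives 10000 nM. Compound 1 `Cc1ccc(CS/C(=C/c2ccc(O)cc2)C(=O)c2ccc(Cl)cc2)cc1` gives 10000 nM, and compound 3 `Cc1ccsc1/C=C(/SCc1ccc(F)cc1)C(=O)c1ccc(Cl)cc1` gives 50000 nM. Compound 1 differs from compound 2 by 4-hydroxyphenyl in place of 3-methylthiophen-2-yl on a double-bonded chain carbon bound to a double-bonded chain carbon, and the step of no change at the digits printed from compound 2 to compound 1 (within the scatter) stays within the scatter of repeated measurements. Compound 3 differs from compound 2 by fluoro in place of methyl on an aromatic carbon, and the step of a 5.0-fold higher number from compound 2 to compound 3 (0.70 log units; beyond the scatter) leaves compound 3 as the weakest growth inhibitor of the three measured compounds, since its distance from each of the other two lies beyond the scatter.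

Compound 4 `O=C(/C(=C\c1ccc(O)cc1)SCc1ccc(F)cc1)c1ccc(Cl)cc1` has not yet been measured in this assay. For the measured compounds named here, it differs from compound 3 by 4-hydroxyphenyl in place of 3-methylthiophen-2-yl on a double-bonded chain carbon bound to a double-bonded chain carbon, which is the same change as the one from compound 2 to compound 1, this time made on a core that differs from the core of compound 2 by fluoro in place of methyl on an aromatic carbon. Going by the values given here, the only guide is the earlier step of no change at the digits printed from compound 2 to compound 1 (within the scatter), which produced no shift, so the step from compound 3 to compound 4 is expected to be small as well, no change at the digits printed from compound 3 to compound 4 (within the scatter). Compound 4 is therefore expected to give about 50000 nM in this assay. The estimate for compound 4 carries a range from 20000 nM to 120000 nM, reflecting that a single prior example of the change is a thin basis.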

Compound 4, concentration for 50% growth inhibition: 25000 nM
Estimate against measurement, compound 4: 2.0-fold (0.30 log units) above; the measured number falls inside the stated range.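

In this assay, putting 4-hydroxyphenyl in place of 3-methylthiophen-2-yl gives a 2.0-fold lower number from compound 3 to compound 4 (0.30 log units; within the scatter), so on this second core the change again stays within the scatter, and the two cores cannot be told apart by this step: the same change on two cores in this assay, no change at the digits printed (within the scatter) from compound 2 to compound 1 and a 2.0-fold lower number (0.30 log units; within the scatter) from compound 3 to compound 4, 2.0-fold (0.30 log units) apart, within the scatter of two such steps
The other change in this set of four compounds, fluoro in place of methyl on an aromatic carbon, can now also be read on a second core; it gives a 2.5-fold higher number from compound 1 to compound 4 (0.40 log units; beyond the scatter), which goes the same way as the earlier step and cannot be told apart from it in size: the same change on two cores in this assay, a 5.0-fold higher number (0.70 log units; beyond the scatter) from compound 2 to compound 3 and a 2.5-fold higher number (0.40 log units; beyond the scatter) from compound 1 to compound 4, 2.0-fold (0.30 log units) apart, within the scatter of two such steps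
Both changes therefore carry across these two cores, but two cores are a small sample, so this does not show that either change would behave the same way on a core outside these four compounds, and it gives no explanation of why the numbers fall as they do.

The compounds shown leave open what other groups would do at the same places, such as an amine or a carboxylic acid in place of the hydroxyl of 4-hydroxyphenyl, or methoxy or trifluoromethyl in place of fluoro. From the compounds shown here alone, the chloro group is common to all four compounds, so what replacing it would do also remains open.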